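Aryl amide variation in the trifluoromethyl diol series

The source may hold more compounds than are shown below. What is called first, only, known or untested is meant among the compounds shown, and "the series" means these compounds.

Measured compounds:
compound 1 `COc1ccc(NC(=O)CCCCCCNC(=O)C(O)(O)C(F)(F)F)cc1`: 4520 nM
compound 2 `Cc1ccc(S(=O)(=O)Nc2ccc(NC(=O)CCCCCCNC(=O)C(O)(O)C(F)(F)F)cc2)cc1`: 17200 nM
compound 3 `Cc1nc(NC(=O)CCCCCCNC(=O)C(O)(O)C(F)(F)F)sc1-c1ccccc1`: 10100 nM

In a functional assay on HCT-116 cells (Homo sapiens) for inhibition, read by colorimetric assay, with a stated time of 3 days (on this read-out higher numbers stand for weaker inhibition and lower numbers for stronger inhibition), compound 1 gives the lowest number of the three measured compounds. Compound 3 stands next to it, and compound 2 furthest away, with a 3.8-fold higher number from compound 1 to compound 2 (0.58 log units; beyond the scatter); both gaps from compound 1 lie beyond the scatter, so compound 1 is the strongest inhibitor on the numbers shown.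

Compound 4 `O=C(CCCCCCNC(=O)C(O)(O)C(F)(F)F)Nc1cccc(Br)c1` is not yet measured. It differs from compound 1 by 3-bromophenyl in place of 4-methoxyphenyl on an amide-type nitrogen. For the measured compounds named here, of the measured steps, only that from compound 1 to compound 2 touches the same aryl amide end of the shared core, and it was modest in size while replacing a group with a different one from the one entering here. Going by the values given here, no measured pair exchanges a methoxy for a bromine, nor moves a substituent around the ring, so there is no direct guide for the change to compound 4.

Given that the one step at this end was modest, compound 4 is expected to stay close to compound 1, with a small step, a 1.3-fold higher number from compound 1 to compound 4 (0.12 log units; within the scatter), that may fall within the scatter. The estimate for compound 4 is 6000 nM, within 2500 nM to 15000 nM.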

Compound 4, half-maximal inhibitory concentration: 3060 nM
Beside the measured number, compound 4's estimate is 2.0-fold (0.29 log units) above it; the measured number falls inside the stated range.
By their numbers in this assay, from the lowest: compounds 4 and 1 (each within the scatter of the next); then compounds 3 and 2 (each within the scatter of the next).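

In this assay, 3-bromophenyl in place of 4-methoxyphenyl on the amide-type nitrogen gives a 1.5-fold lower number from compound 1 to compound 4 (0.17 log units; within the scatter) and so stays within the scatter, whereas the other measured change at this end gives a 3.8-fold higher number from compound 1 to compound 2 (0.58 log units; beyond the scatter) and lies beyond it. This position therefore accepts a second substituted phenyl, and the hydrogen-bond acceptor of 4-methoxyphenyl is absent from 3-bromophenyl with no step beyond the scatter. Nothing available bears on the reason for this result.

The effects of the bromine and of its place on the ring remain unseparated, and 4-bromophenyl and 3-methoxyphenyl on the same nitrogen would divide them. Also open, from the compounds shown here alone, is whether an amine or a carboxylic acid on the phenyl ring, or a longer chain in the shared core, would move the number beyond the scatter.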